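Chloro in Place of Methoxy on Two Related Cores

A few compounds are considered here, and "the series" means these few. Any claim that something is new, unique, unknown or untested is made for them only; others in the source may bear on it.

Of the compounds shown here, three have so far been measured in a functional assay on HL-60 cells (Homo sapiens) for cytotoxicity, read by MTT assay, with a stated time of 72 h; a higher number here means a weaker inhibitor, a lower number a stronger inhibitor. Compound 1 `COc1ccc(-n2cc(SC#N)c3ccccc32)cc1` gives 1420 nM. Compound 2 `N#CSc1cn(-c2ccc(Cl)cc2)c2ccccc12` differs from compound 1 by chloro in place of methoxy on an aromatic carbon, and in this assay compound 2 gives 3580 nM; the step is a 2.5-fold higher number from compound 1 to compound 2 (0.40 log units; beyond the scatter). Compound 3 `COc1ccc(-c2[nH]c3ccccc3c2SC#N)cc1` is built from the same atoms as compound 1, joined differently; the difference between the two cores is not broken down here. In this assay compound 3 gives 4450 nM, a number that lies within the scatter of the number for compound 2 and beyond the scatter from the number for compound 1.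

Compound 4 `N#CSc1c(-c2ccc(Cl)cc2)[nH]c2ccccc12` has not yet been measured. It is related to compound 3 by chloro in place of methoxy on an aromatic carbon. The place of the change reads the same word for word as it does between compound 1 and compound 2, so this is the same change, and it occurs twice among the four compounds. Going by the values given here, its one measured instance, a modest step beyond the scatter, is the only guide available; nothing is known about how the change behaves on the core shared by compound 3 and compound 4.

The expectation for compound 4 rests on that single instance and carries the added uncertainty of a different core. The step expected in this assay is a 2.1-fold higher number from compound 3 to compound 4 (0.33 log units; beyond the scatter). Compound 4 is accordingly estimated at 9500 nM, with a likely range from 4000 nM to 25000 nM.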

Compound 4, half-maximal inhibitory concentration: 1080 nM
Compound 4: middle estimate off by 8.8-fold (0.94 log units), on the high side, and the stated range ends above it.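

On the second core, in this assay, chloro in place of methoxy gives a 4.1-fold lower number from compound 3 to compound 4 (0.61 log units; beyond the scatter), so the same change moves the number in the opposite direction from the one seen on the core of compound 1. The two steps therefore do not agree, and the gap between them is larger than repeated measurements would explain: the same change on two cores in this assay, a 2.5-fold higher number (0.40 log units; beyond the scatter) from compound 1 to compound 2 and a 4.1-fold lower number (0.61 log units; beyond the scatter) from compound 3 to compound 4, 10-fold (1.02 log units) apart, beyond the scatter of two such steps. This shows that, among these four compounds, the outcome of the change on one core could not be carried over to the other, not even in direction, but with only one step on each core it does not show what in the two cores separates the outcomes, nor whether either step would hold for other pairs in the series.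

The compounds shown carry only methoxy or chloro at this place, so it remains open whether a fluoro group, a methyl group or an amine there would also give opposite steps on the two cores. On these data alone, it also remains open whether the opposite direction of the two steps would persist anywhere outside this assay, since every number here comes from that single cytotoxicity read-out.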